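Chalcone-lactone hybrids: removing two fluorines from compound 1

The source may report more compounds than this note shows. Statements on the series, on what has been measured and on what is new or still open speak of the compounds shown alone.

Compound 1 `O=C(COc1ccc(C(=O)/C=C/c2ccc(F)c(F)c2)cc1)N[C@H]1CCOC1=O` is a chalcone-lactone hybrid measured in a functional assay on DU-145 cells (Homo sapiens) for antiproliferative activity, read by MTT assay, with a stated time of 72 h (a lower number here means a stronger inhibitor, a higher number a weaker inhibitor), where compound 1 gives 19800 nM. Within the data shown here, this is the only numerical value in the set. Compound 2 `CCCCCCCCCCSC(=S)N[C@H]1CCOC1=O` reaches only a limit of the assay in this assay, at > 64000 nM. Among the measured compounds shown here, that limit of > 64000 nM in this assay, at which 1 of the 2 values shown sits, is a boundary rather than a measured number, so no step can be drawn between compound 2 and compound 1.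

Compound 3 `O=C(COc1ccc(C(=O)/C=C/c2ccccc2)cc1)N[C@H]1CCOC1=O` differs from compound 1 by phenyl in place of 3,4-difluorophenyl on a double-bonded chain carbon bound to a double-bonded chain carbon. For the measured compounds named here, no measured pair in this set carries a comparable change, so the size of this step is not anchored by any neighbouring data. The step from compound 1 to compound 3 is expected to be small, a 1.3-fold higher number from compound 1 to compound 3 (0.12 log units; within the scatter), in the direction of slightly weaker inhibition, and most likely within the scatter of repeated measurements. Compound 3 is therefore estimated at 26000 nM, with a range from 10000 nM to 64000 nM in this assay.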

Compound 3, half-maximal inhibitory concentration: 48300 nM
Estimate against measurement, compound 3: 1.9-fold (0.27 log units) below, within the range that was stated.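

In this assay, taking phenyl in place of 3,4-difluorophenyl on a double-bonded chain carbon bound to a double-bonded chain carbon gives a 2.4-fold higher number from compound 1 to compound 3 (0.39 log units; beyond the scatter) and so shows that this position responds to the change, though only modestly. Among these compounds, this is the first readable step in the set, and it shows that the two fluorines together bear on the number, but not whether each contributes. Nothing measured here gives a cause for this step.

The compounds shown leave open whether a single fluorine on the phenyl would carry the step alone, and whether a chlorine or a methoxy group at this position would move the number further. Also open, from the compounds shown here alone, is whether the same exchange would give a step of like size on a core carrying an amine in place of the lactone.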